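Thiosemicarbazone analogues: exchanging pyrrole for thiophene

A few compounds are considered here, and "the series" means these few. Any claim that something is new, unique, unknown or untested is made for them only; others in the source may bear on it.

Compound 2 `CC1=CC[C@H](C(C)(C)NC(=S)N/N=C/c2ccc[nH]2)CC1` was tested in a functional assay on 786-0 cells (Homo sapiens) for inhibition, read by sulforhodamine B assay, with a stated time of 48 h (on this read-out lower numbers stand for stronger inhibition of growth and higher numbers for weaker inhibition of growth), and gives 20800 nM. Among the measured compounds shown here, this is the highest of the two numbers measured so far. The nearest compound is compound 1 `COc1ccc(/C=N/NC(=S)NC(C)(C)[C@H]2CC=C(C)CC2)cc1`, which in this assay gives 8900 nM. For the measured compounds named here, the one step that connects them, a 2.3-fold higher number from compound 1 to compound 2 (0.37 log units; beyond the scatter), came from placing 1H-pyrrol-2-yl in place of 4-methoxyphenyl on a carbon with a double bond to nitrogen.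

Compound 3 `CC1=CC[C@H](C(C)(C)NC(=S)N/N=C/c2cccs2)CC1` has not yet been measured. It differs from compound 2 by thiophen-2-yl in place of 1H-pyrrol-2-yl on a carbon with a double bond to nitrogen. Going by the values given here, no measured step addresses this exchange of one five-membered aromatic ring with 1 hetero atom for another, so the step from compound 1 to compound 2, which swapped a six-membered aromatic ring for the five-membered one, is the nearest guide, and it bears on the present change indirectly at best. Compound 3 is therefore expected to lie close to compound 2, with a step of a 1.6-fold lower number from compound 2 to compound 3 (0.20 log units; within the scatter) that is expected to fall within the scatter. The estimate for compound 3 in this assay is 13000 nM, in the range 5500 nM to 30000 nM.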

Compound 3, concentration for 50% growth inhibition: 11500 nM
The estimate for compound 3 lay 1.1-fold (0.05 log units) above the measured number, within the range that was stated.
By their numbers in this assay, from the lowest: compounds 1, 3 and 2 (each within the scatter of the next, the first and the last beyond it).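

In this assay, the exchange on the carbon with a double bond to nitrogen gives a 1.8-fold lower number from compound 2 to compound 3 (0.26 log units; within the scatter), so at this place a ring with a hydrogen-bond donor and no acceptor and a ring with an acceptor and no donor cannot be told apart. The other exchange gives a 1.3-fold higher number from compound 1 to compound 3 (0.11 log units; within the scatter), which shows that thiophen-2-yl cannot be told apart from 4-methoxyphenyl either, although the step of a 2.3-fold higher number from compound 1 to compound 2 (0.37 log units; beyond the scatter) separates 4-methoxyphenyl from 1H-pyrrol-2-yl; the three compounds therefore form a chain of overlapping values rather than a clear order, and only its two ends are distinct. No supporting measurement is available to explain these results.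

The compounds shown leave open whether any group at this place would move the number well beyond the scatter in either direction, since all three values lie close together. A furan-2-yl ring, or a phenyl ring carrying an amine or a carboxylic acid in place of the methoxy group, would test whether this place tolerates such exchanges as broadly as these three compounds suggest.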